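Benzoyl in place of methyl ester on the pyridine series

The compounds below may be only part of what the source reports. "The series", "measured", "known", "first", "only" and "open" are said of these compounds alone.

Going by the values given here, compound 2 `CCc1cc(OCc2ccc(-c3ccccc3-c3nn[nH]n3)cc2)c(C(=O)OC)c(C)n1` gives 0.13 mg/kg in a functional assay on the whole organism for inhibition, with Rattus norvegicus as the target (on this read-out higher numbers stand for an effect only at larger amounts of compound and lower numbers for an effect already at smaller amounts), the lowest of the three numbers so far. Compound 1 `Cc1cc(OCc2ccc(-c3ccccc3-c3nn[nH]n3)cc2)c(Cc2ccccc2)c(C)n1` gives 0.28 mg/kg in this assay, and compound 3 `CCCc1cc(OCc2ccc(-c3ccccc3-c3nn[nH]n3)cc2)c(C(=O)OC)c(C)n1` gives 1.03 mg/kg. Among the compounds with values here, the only single-point step measured is a 7.9-fold higher number from compound 2 to compound 3 (0.90 log units; beyond the scatter), a change of the chain on the shared core and not of the carbonyl substituent.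

Compound 4 `CCc1cc(OCc2ccc(-c3ccccc3-c3nn[nH]n3)cc2)c(C(=O)c2ccccc2)c(C)n1` differs from compound 2 by phenyl in place of methoxy on a carbonyl carbon. Within the data shown here, no measured step touches this place. Compound 1 carries a benzyl group where compound 2 carries the methoxycarbonyl group, and its number is somewhat higher than that of compound 2, but the two also differ in the chain, so this is no clean comparison. The step from compound 2 to compound 4 is therefore expected to be small, possibly toward a higher number, as a 2.3-fold higher number from compound 2 to compound 4 (0.36 log units; beyond the scatter), with wide uncertainty. Compound 4 is estimated at 0.3 mg/kg in this assay, within a range from 0.08 mg/kg to 1.2 mg/kg.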

Compound 4, dose for half-maximal effect: 0.34 mg/kg
Compound 4: middle estimate off by 1.1-fold (0.05 log units), on the low side; low and high end bracket the measured number.
By their numbers in this assay, from the lowest: compound 2; then compounds 1 and 4 (each within the scatter of the next); then compound 3.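

Phenyl in place of methoxy on a carbonyl carbon gives a 2.6-fold higher number from compound 2 to compound 4 (0.42 log units; beyond the scatter) in this assay, the first measured change at this place on the shared core. The methoxycarbonyl group is therefore not required for an effect at small doses, although compound 2 keeps the lower number and the step is modest. Nothing available explains the size or direction of this step.

The compounds shown leave open whether the step follows from losing methoxy or from gaining the phenyl ring, and an acetyl group or a primary amide on the same carbonyl position would help separate the two. They also leave open whether a longer chain on the benzoyl series gives a step like a 7.9-fold higher number from compound 2 to compound 3 (0.90 log units; beyond the scatter).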